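The source may hold more compounds than are shown below. What is called first, only, known or untested is meant among the compounds shown, and "the series" means these compounds.

Going by the values given here, in a functional assay on T47D cells (Homo sapiens) for cytotoxicity, read by CCK-8 assay and cell counting, with stated times of 4 h and 2 days (a lower number here means a stronger inhibitor, a higher number a weaker inhibitor), three compounds have numbers so far. Compound 1 `Oc1cccc(-c2cc(-c3ccccc3Cl)cc(-c3ccsc3)n2)c1` gives 680 nM and compound 2 `Oc1cccc(-c2cc(-c3ccccc3Cl)cc(-c3ccccc3)n2)c1` gives 680 nM on this read-out, while compound 3 `Oc1cccc(-c2cc(-c3cccc(Cl)c3)cc(-c3ccco3)n2)c1` gives 680 nM as well. Compound 3 therefore stands level with both of the others.

Compound 4 `Oc1cccc(-c2cc(-c3cccc(Cl)c3)cc(-c3cccs3)n2)c1` has not yet been measured. It differs from compound 3 in one place thiophen-2-yl in place of furan-2-yl on an aromatic carbon and the change is thiophen-2-yl in place of furan-2-yl on an aromatic carbon, next to the ring nitrogen. Both groups are five-membered aromatic rings with 1 hetero atom, so one ring of the same size replaces another.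

Among the compounds with values here, the one measured step that swaps one aromatic ring for another shows no change at the digits printed from compound 1 to compound 2 (within the scatter) with phenyl in place of thiophen-3-yl. That step bears on the question only loosely. Within the data shown here, it involves different rings, compounds 1 and 2 also differ from compound 3 elsewhere, and no measured pair makes the furan-2-yl to thiophen-2-yl swap directly.

In this assay the expected result is no change at the digits printed from compound 3 to compound 4 (within the scatter) with no move in either direction beyond the scatter. Compound 4 is estimated at 680 nM with an expected range from 300 nM to 1500 nM on this thin evidence.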

Compound 4, half-maximal inhibitory concentration: 680 nM
Estimate against measurement, compound 4: no gap at the digits printed; measured number inside the range.
By their numbers in this assay, from the lowest: compounds 1, 2, 3 and 4 (each within the scatter of the next).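

In this assay, replacing furan-2-yl with thiophen-2-yl on the aromatic carbon next to the ring nitrogen gives no change at the digits printed from compound 3 to compound 4 (within the scatter), a direct comparison in which only the ring oxygen gives way to sulfur. Going by these compounds alone, the earlier step, no change at the digits printed from compound 1 to compound 2 (within the scatter), came from a different ring swap with the chlorine placed differently on the neighbouring ring, so this is the first pair to test these two five-membered rings against each other with the 3-chlorophenyl group in place. At this position and with this background, the assay does not distinguish furan-2-yl from thiophen-2-yl, and no accompanying measurement offers an explanation for that result.

Every group shown at this carbon is an aromatic ring, so it remains open whether an amine, a carboxylic acid or a longer alkyl chain there would keep the number in the same place. From the compounds shown here alone, it is also open whether the furan-2-yl to thiophen-2-yl swap would give the same result with a different group in place of the 3-chlorophenyl or 3-hydroxyphenyl group.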